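This account rests on a few compounds, and the source may have more. Where it says the series, first, only, none or still open, it means among the compounds named here.

In an ADME assay on microsomes from liver (Rattus norvegicus) for metabolic stability, read by LC-MS, with a stated time of 10 min, tested at 0.5 uM (on this read-out lower numbers stand for a less stable compound and higher numbers for a more stable compound), compound 2 `c1cnc2c(c1)CCC[C@@H]2N(CCCN1CCNCC1)Cc1nc2ccccc2[nH]1` gives 29%. Among the compounds with values here, of the three compounds measured so far, compound 2 stands second: compound 1 `c1ccc2c(c1)CN[C@@H](CN(CC[C@H]1CCCNC1)[C@H]1CCCc3cccnc31)C2` gives 55%, a number higher than that of compound 2 by more than the usual scatter, while compound 3 `CN1CCN(CCCN(C[C@H]2Cc3ccccc3CN2C)[C@H]2CCCc3cccnc32)CC1` gives 2%, a number lower than that of compound 2 by more than the scatter. Compound 4 `c1cnc2c(c1)CN[C@@H](CN(CCCN1CCNCC1)[C@H]1CCCc3cccnc31)C2` has not yet been measured in this assay. It differs from compound 2 in one place: a group of 10 heavy atoms (8 carbon, 2 nitrogen; one six-membered non-aromatic ring with 1 hetero atom, one six-membered aromatic ring with 1 hetero atom) in place of a group of 9 heavy atoms (7 carbon, 2 nitrogen; one five-membered aromatic ring with 2 hetero atoms, one six-membered aromatic ring of carbon only), on a saturated chain carbon bound to an amine nitrogen. Within the data shown here, no measured pair shows this exact change, so its size can only be judged by analogy. The group that enters in compound 4 is carried by compound 1, and compound 1 gives 55%. An upward step beyond the scatter is therefore expected, namely a number 16 percentage points higher from compound 2 to compound 4 (beyond the scatter) in this assay. Compound 4 is estimated to give 45%, with a range from 25% to 65%.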

Compound 4, percent of the compound remaining: 79%
Beside the measured number, compound 4's estimate is 34 percentage points below it; measured number above the stated range.
By their numbers in this assay, from the lowest: compound 3; then compound 2; then compound 1; then compound 4.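

Within the data shown here, exchanging the 1H-benzimidazol-2-yl group, on a saturated chain carbon bound to an amine nitrogen, for a group with a six-membered non-aromatic ring and a six-membered aromatic ring gives a number 50 percentage points higher from compound 2 to compound 4 (beyond the scatter) in this assay and is the only step here between compounds that differ in one place. It shows that the read-out depends strongly on the group at this position. No measurement at hand gives a reason for this step. Which of the two rings carries the step stays open, and so does whether a plain phenyl group or a simple amine at this place would give a similar number.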